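4-nitrophenyl to 4-fluorophenyl in the series

The source may hold more compounds than are shown below. What is called first, only, known or untested is meant among the compounds shown, and "the series" means these compounds.

Measured so far in a functional assay on HT-29 cells (Homo sapiens) for inhibition, with a stated time of 72 h (a higher number here means a weaker inhibitor, a lower number a stronger inhibitor), are these compounds
- compound 1 `COc1ccc(S(=O)(=O)N2CCc3cccc(-c4ccc([N+](=O)[O-])cc4)c32)cc1` gives 51.8 nM
- compound 2 `COc1ccc(S(=O)(=O)N2CCc3cccc(-c4ccc(N(C)C)cc4)c32)cc1` gives 467 nM
- compound 3 `COc1ccc(S(=O)(=O)N2CCc3cccc(-c4cc(OC)c(OC)c(OC)c4)c32)cc1` gives 5100 nM

Compound 1 holds the lowest of the three numbers, and both other values lie beyond the scatter from it. Compound 4 `COc1ccc(S(=O)(=O)N2CCc3cccc(-c4ccc(F)cc4)c32)cc1` has not been measured. Its change from compound 1 is fluoro in place of nitro on an aromatic carbon and nothing else.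

One measured step also removes the nitro group, and it gives a 9.0-fold higher number from compound 1 to compound 2 (0.95 log units; beyond the scatter) in this assay as its result. Among the measured compounds shown here, compound 3 has the highest number, but no single-place step links it to compound 1, so it sets no size for this change. For the measured compounds named here, no measured compound carries fluoro, which leaves the size uncertain. A step in the same direction as the measured one, but smaller, is expected, and the estimate is a 3.1-fold higher number from compound 1 to compound 4 (0.49 log units; beyond the scatter) for this pair. The estimated value for compound 4 is 160 nM with an expected range from 40 nM to 650 nM in this assay.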

Compound 4, half-maximal inhibitory concentration: 85.5 nM
Estimate against measurement, compound 4: 1.9-fold (0.27 log units) above; measured number inside the range.
By their numbers in this assay, from the lowest: compounds 1 and 4 (each within the scatter of the next); then compound 2; then compound 3.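

In this assay the change from 4-nitrophenyl to 4-fluorophenyl gives a 1.7-fold higher number from compound 1 to compound 4 (0.22 log units; within the scatter) so compounds 1 and 4 cannot be told apart, and at this place the nitro group, with its 3 heavy atoms and 2 hydrogen-bond acceptors, can be replaced by a single fluoro atom without a step beyond the scatter. The loss seen with dimethylamino does not appear with fluoro, although both changes remove nitro. The fluoro compound stands apart from the dimethylamino compound, with a 5.5-fold lower number from compound 2 to compound 4 (0.74 log units; beyond the scatter) as the step. No measurement at hand accounts for the difference between these groups.

The compounds shown leave open how a nitrile, a primary amine or a carboxylic acid would read at this place. Going by these compounds, whether the ring needs any group there at all also stays open.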